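Amide Replacing an Ester: Predicting Compound 3

A few compounds are considered here, and "the series" means these few. Any claim that something is new, unique, unknown or untested is made for them only; others in the source may bear on it.

Measured so far:
compound 1 `COC(=O)c1cccn1-c1ccc(Nc2ncc(Cl)c(Nc3ccccc3NS(C)(=O)=O)n2)c(OC)c1` gives 790 nM
compound 2 `COc1cc(-n2cccc2C(=O)O)ccc1Nc1ncc(Cl)c(Nc2ccccc2NS(C)(=O)=O)n1` gives 90 nM

In a functional assay on KARPAS-299 cells (Homo sapiens) for antiproliferative activity, read by MTT assay, with a stated time of 4 h (a higher number here means a weaker inhibitor, a lower number a stronger inhibitor), compound 1 has the higher of the two numbers, the weaker of the pair. For the measured compounds named here, the only measured step, an 8.8-fold lower number from compound 1 to compound 2 (0.94 log units; beyond the scatter), turns the methyl ester into the free acid. Compound 3 `COc1cc(-n2cccc2C(=O)N2CCC(C)CC2)ccc1Nc1ncc(Cl)c(Nc2ccccc2NS(C)(=O)=O)n1` instead changes the same carbonyl group in another way: 4-methylpiperidin-1-yl in place of methoxy on a carbonyl carbon. Going by the values given here, no measured step covers an ester turned into an amide, so the acid result offers only an indirect hint. The expectation is a step of a 1.6-fold lower number from compound 1 to compound 3 (0.20 log units; within the scatter), within or near the scatter. Compound 3 is therefore estimated at 500 nM, between 150 nM and 1600 nM.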

Compound 3, half-maximal inhibitory concentration: 1370 nM
Beside the measured number, compound 3's estimate is 2.7-fold (0.44 log units) below it; the measured number falls inside the stated range.
By their numbers in this assay, from the lowest: compound 2; then compounds 1 and 3 (each within the scatter of the next).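

Putting 4-methylpiperidin-1-yl in place of methoxy on this carbonyl carbon gives a 1.7-fold higher number from compound 1 to compound 3 (0.24 log units; within the scatter), so the ester and this ring-bearing amide cannot be told apart here. The free acid remains clearly stronger than the amide, with a 15-fold higher number from compound 2 to compound 3 (1.18 log units; beyond the scatter). Nothing available explains this difference between the acid and the amide.

From the compounds shown here alone, it remains open whether a smaller amide, such as the primary amide or the dimethylamide, would match the ester or come closer to the acid. Whether a tetrazole in place of the carboxylic acid would keep the acid's number is also unknown.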